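A 4-methoxyphenyl swap at the assay limit

The compounds below may be only part of what the source reports. "The series", "measured", "known", "first", "only" and "open" are said of these compounds alone.

In a functional assay on DU-145 cells (Homo sapiens) for antiproliferative activity, read by MTT assay, with a stated time of 48 h (a lower number here means a stronger inhibitor, a higher number a weaker inhibitor), compound 1 `C/C(=C\CC/C(C)=C/CC[C@@H]1[C@@]2(C)CCC(=O)C(C)(C)[C@H]2CC[C@@]1(C)O)CC/C=C(\C)C(=O)OCc1cn(-c2ccccc2Br)nn1` gives > 150000 nM, which is a limit and not a number. Compound 2 `C/C(=C\CC/C(C)=C/CC[C@@H]1[C@@]2(C)CCC(=O)C(C)(C)[C@H]2CC[C@@]1(C)O)CC/C=C(\C)C(=O)OCc1cn(-c2ccccc2C)nn1` gives > 150000 nM, which is also only a limit. Among the compounds with values here, the one measured change, methyl in place of bromo on an aromatic carbon, is a step that the two limits leave unreadable from compound 1 to compound 2. The evidence so far is therefore (the limit of > 150000 nM in this assay, at which 2 of the 2 values shown sit).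

Compound 3 `COc1ccc(-n2cc(COC(=O)/C(C)=C/CC/C(C)=C/CC/C(C)=C/CC[C@@H]3[C@@]4(C)CCC(=O)C(C)(C)[C@H]4CC[C@@]3(C)O)nn2)cc1` shares the core of these compounds and differs from compound 2 as follows: 4-methoxyphenyl in place of 2-methylphenyl on an aromatic nitrogen. In words, 4-methoxyphenyl stands in place of 2-methylphenyl on an aromatic nitrogen. Within the data shown here, no measured step gives a size for this change, so no step beyond the scatter is expected in this assay, and compound 3 is expected to stay near the limit. The estimated change is a number no higher from compound 2 to compound 3 (the limit leaves the size open). For compound 3 the expected value is 150000 nM, with an estimated range from 70000 nM to 300000 nM.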

Compound 3, half-maximal inhibitory concentration: 135000 nM
The estimate for compound 3 lay 1.1-fold (0.05 log units) above the measured number, within the range that was stated.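

With 4-methoxyphenyl on the aromatic nitrogen, the series gains its first reading that is a number and not a limit: in this assay, compound 3 gives 135000 nM. Read against the earlier limits, this change is an at least 1.1-fold lower number from compound 2 to compound 3 (0.04 log units; that floor lies within the scatter) and an at least 1.1-fold lower number from compound 1 to compound 3 (0.04 log units; that floor lies within the scatter); each of these is only a floor, and the true size of the step stays open. Even so, the compounds shown remain close to the edge of what the assay can read: the limit of > 150000 nM in this assay, at which 2 of the 3 values shown sit.

The swap changes both the group on the phenyl ring and its number on that ring, so compound 3 does not separate these two changes. As far as these compounds go, it also remains open whether an amine or a carboxylic acid on that ring, or a longer chain in place of the methoxy group, would bring the number down further.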